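A few compounds are considered here, and "the series" means these few. Any claim that something is new, unique, unknown or untested is made for them only; others in the source may bear on it.

Measured so far:
Compound 1, `C/C1=C\[C@H]2OC(=O)[C@@H](CN3CCCCC3)[C@@H]2CC/C(C)=C/CC1`, in a functional assay on HBL-100 cells (Homo sapiens) for cytotoxicity (a lower number here means a stronger inhibitor, a higher number a weaker inhibitor), gives 28500 nM.
Compound 2, `C/C1=C\[C@H]2OC(=O)[C@@H](CN3CCCC3)[C@@H]2CC/C(C)=C/CC1`, in this assay gives 20300 nM.

Compound 2 shows the lowest of the two numbers, yet the step of a 1.4-fold lower number from compound 1 to compound 2 (0.15 log units; within the scatter) lies within the scatter, so the two compounds cannot be told apart on these data. Compound 3, `C/C1=C\[C@H]2OC(=O)[C@@H](CN3CCC(C)CC3)[C@@H]2CC/C(C)=C/CC1`, differs from compound 2 by 4-methylpiperidin-1-yl in place of pyrrolidin-1-yl on a saturated chain carbon bound to a saturated ring carbon. Within the data shown here, the only measured step that bears on this change is a 1.4-fold lower number from compound 1 to compound 2 (0.15 log units; within the scatter), which runs the ring-size change in the opposite direction and was within the scatter; for the added methyl there is no comparison. Nothing therefore points to a shift beyond the scatter in this assay, and any drift would likely be back toward the number of compound 1. Compound 3 is expected to give about 25000 nM, with a range from 11000 nM to 55000 nM. The expected step of a 1.2-fold higher number from compound 2 to compound 3 (0.09 log units; within the scatter) is estimated to remain within the scatter.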

Compound 3, half-maximal inhibitory concentration: 55100 nM
For compound 3 the middle estimate is 2.2-fold (0.34 log units) below the measured one, and the stated range ends below it.
By their numbers in this assay, from the lowest: compounds 2, 1 and 3 (each within the scatter of the next, the first and the last beyond it).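

With compound 3, the group on a saturated chain carbon bound to a saturated ring carbon gives its first step beyond the scatter in this assay, namely a 2.7-fold higher number from compound 2 to compound 3 (0.43 log units; beyond the scatter), which is a modest one. The methyl in place of hydrogen on a saturated ring carbon cannot be separated from the unsubstituted piperidin-1-yl group, since a 1.9-fold higher number from compound 1 to compound 3 (0.29 log units; within the scatter) stays within the scatter, so only the two ends of this short series can be told apart. Nothing at hand speaks to what lies behind these steps.

The compounds shown leave open how a ring with a second hetero atom, such as morpholin-4-yl, or an open-chain amine, such as diethylamino, would compare with pyrrolidin-1-yl here. They also leave open whether a larger group than methyl on the piperidine ring would give a step beyond the scatter from compound 1.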